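The compounds below may be only part of what the source reports. "The series", "measured", "known", "first", "only" and "open" are said of these compounds alone.

Working notes on the series. Two compounds have numbers in a functional assay on HL-60 cells (Homo sapiens) for antiproliferative activity, read by MTT assay, with a stated time of 72 h (on this read-out lower numbers stand for stronger inhibition and higher numbers for weaker inhibition), so far. Compound 1 `COc1ccc(C(=O)N(C)c2ccc3[nH]c(-c4n[nH]c5ccccc45)cc3n2)cc1` gives 3320 nM in this assay. Within the data shown here, compound 2 `CN(c1ccc2[nH]c(-c3n[nH]c4ccccc34)cc2n1)S(=O)(=O)c1ccccc1` gives 3700 nM in this assay, which is the higher of the two numbers, with compound 1 as its only neighbour. Among the measured compounds shown here, the single measured step, a 1.1-fold higher number from compound 1 to compound 2 (0.05 log units; within the scatter), is within the scatter, so the two measured compounds are not separable in this assay.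

Compound 3 `Cc1ccc(S(=O)(=O)N(C)c2ccc3[nH]c(-c4n[nH]c5ccccc45)cc3n2)cc1` is the next member. It differs from compound 2 by methyl in place of hydrogen on an aromatic carbon of the phenylsulfonyl, giving (4-methylphenyl)sulfonyl. For the measured compounds named here, no measured step involves a methyl on this ring, and the one step on record, a 1.1-fold higher number from compound 1 to compound 2 (0.05 log units; within the scatter), concerns a change at a different place and is within the scatter itself. Going by the values given here, nothing among the measured compounds therefore points to a shift beyond the scatter in this assay for compound 3, and the estimate for compound 3 is 3500 nM in this assay, with a range from 1200 nM to 10000 nM. The expected step, a 1.1-fold lower number from compound 2 to compound 3 (0.02 log units; within the scatter), is an estimate of no change beyond the scatter.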

Compound 3, half-maximal inhibitory concentration: 3030 nM
For compound 3 the middle estimate is 1.2-fold (0.06 log units) above the measured one; the range from low to high includes it.
By their numbers in this assay, from the lowest: compounds 3, 1 and 2 (each within the scatter of the next).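

In this assay, methyl in place of hydrogen on an aromatic carbon, para to a large group, turns the phenylsulfonyl into (4-methylphenyl)sulfonyl and gives a step within the scatter (a 1.2-fold lower number from compound 2 to compound 3 (0.09 log units; within the scatter)), so this position on the ring now has a measured step and the read-out does not separate hydrogen from methyl there. The second new step compares (4-methylphenyl)sulfonyl with (4-methoxyphenyl)carbonyl on the same nitrogen and is also within the scatter (a 1.1-fold lower number from compound 1 to compound 3 (0.04 log units; within the scatter)), which means that the sulfonyl and carbonyl compounds remain inseparable when the ring of the sulfonyl compound carries a methyl as well as when it carries only hydrogen. No measurement shown here bears on why these three compounds cannot be told apart.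

The compounds shown cover only hydrogen and methyl at this place on the sulfonyl ring, so it remains open whether an amine, a carboxylic acid or a longer chain such as butyl would give a step beyond the scatter. Also open, on these data alone, is what happens when the methyl on the nitrogen gives way to hydrogen, since all three compounds carry that methyl.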